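Trimming a Dimethylamino Tail: Compound 3 to Compound 4

The compounds below may be only part of what the source reports. "The series", "measured", "known", "first", "only" and "open" are said of these compounds alone.

Measured compounds:
compound 1 `CCN(Cc1ccccc1)Cc1ccc(CN2CCc3ccc(OS(N)(=O)=O)cc3C2)cc1` gives 1%
compound 2 `NS(=O)(=O)Oc1ccc2c(c1)CN(C(=O)c1ccc(N3CCN(Cc4ccccc4)CC3)cc1)CC2` gives 20.8%
compound 3 `CN(C)CCN(Cc1ccccc1)c1cccc(C(=O)N2CCc3ccc(OS(N)(=O)=O)cc3C2)c1` gives 0%

All three share a core and were tested in an assay on HEK293 cells for inhibition of Steryl-sulfatase (Homo sapiens), tested at 0.1 uM; on this read-out higher numbers stand for a stronger effect at the one concentration tested and lower numbers for a weaker effect. Compound 3 stands at the bottom of the three numbers: its nearest neighbour is compound 1, which sits higher by an amount that lies within the scatter, so the two cannot be told apart. Compound 2 is the only one of the three that reads beyond the scatter above compound 3.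

Compound 4 `CCCN(Cc1ccccc1)c1cccc(C(=O)N2CCc3ccc(OS(N)(=O)=O)cc3C2)c1` differs from compound 3 in a single place: methyl in place of dimethylamino on a saturated chain carbon, two bonds along the chain from a nitrogen on an aromatic ring. The chain that carries the dimethylamino group in compound 3 is thereby shortened to a propyl group on the nitrogen on the aromatic ring.

Among the compounds with values here, nothing among the measured compounds shows what this kind of trimming does in this assay, since no pair differs in only that spot. With compound 3 already at the floor of the range, the expected step from compound 3 to compound 4 is a number 3 percentage points higher from compound 3 to compound 4 (within the scatter), that is, none beyond the scatter. Compound 4 is therefore estimated at 3%, within a range from 0% to 15%.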

Compound 4, a percentage reported as inhibition, at one concentration (the size of the read-out at that concentration, not a potency): 23.1%
Compound 4: the middle estimate sits 20.1 percentage points below what was measured, outside the stated range (above it).
By their numbers in this assay, from the lowest: compounds 3 and 1 (each within the scatter of the next); then compounds 2 and 4 (each within the scatter of the next).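

Methyl in place of dimethylamino, on a saturated chain carbon two bonds along the chain from a nitrogen on an aromatic ring, gives a number 23.1 percentage points higher from compound 3 to compound 4 (beyond the scatter) in this assay and so turns the 2-(dimethylamino)ethyl group into a propyl group. This is the only pair shown that differs in one place, and it gives the first direct sign that this position matters: a change confined to the end of this chain moves the read-out by more than repeated measurements would, and it does so with the smaller group. Nothing measured here accounts for the step, so it stands as an observation without a known cause.

From the compounds shown here alone, whether the step follows from losing the amine or from some other difference between the two chains stays open, and a 2-methoxyethyl group, a 2-hydroxyethyl group or a longer chain such as butyl on the same nitrogen would help to separate these readings. Going by these compounds, it is also open whether the same trimming would give a step of similar size on a compound with a different core, since this single pair speaks only for compound 3 and compound 4.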